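Swapping the Aryl Ring of the Benzyl Group

This account rests on a few compounds, and the source may have more. Where it says the series, first, only, none or still open, it means among the compounds named here.

Among the measured compounds shown here, in a functional assay on Ehrlich cells (Mus musculus) for cytotoxicity, read by MTT assay, with a stated time of 24 h (on this read-out lower numbers stand for stronger inhibition and higher numbers for weaker inhibition), compound 2 `Cn1nc(-c2nnc(SCc3ccc(C(F)(F)F)cc3)o2)cc1-c1ccc(C(F)(F)F)cc1` gives 20500 nM, the lower of the two numbers measured so far, while compound 1 `Cn1nc(-c2nnc(S)o2)cc1-c1ccc(C(F)(F)F)cc1` gives 68300 nM. For the measured compounds named here, the only measured step, a 3.3-fold lower number from compound 1 to compound 2 (0.52 log units; beyond the scatter), concerns adding the benzyl group to the sulfur and says nothing about changing the ring carried by that benzyl group. Compound 3 `Cn1nc(-c2nnc(SCc3cccc([N+](=O)[O-])c3)o2)cc1-c1ccc(C(F)(F)F)cc1` differs from compound 2 by 3-nitrophenyl in place of 4-(trifluoromethyl)phenyl on a saturated chain carbon bound to a sulfur. Going by the values given here, with no measured step bearing on this change, no shift beyond the scatter is expected in this assay, and compound 3 is expected to give 25000 nM, between 8000 nM and 80000 nM, which means a 1.2-fold higher number from compound 2 to compound 3 (0.09 log units; within the scatter).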

Compound 3, half-maximal inhibitory concentration: > 100000 nM
Compound 3 was reported as a limit; the forecaster's own chance of this, stated with the estimate: 10%; middle value at least 4.0-fold (0.60 log units) from the limit.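

In this assay, the ring on the saturated chain carbon bound to a sulfur proves not to be freely exchangeable: 3-nitrophenyl in place of 4-(trifluoromethyl)phenyl gives an at least 4.8-fold higher number from compound 2 to compound 3 (0.68 log units; beyond the scatter) on this read-out. Compound 3 is reported only as a limit, not as a number: the limit of > 100000 nM in this assay, at which 1 of the 3 values shown sits. With 3-nitrobenzyl in place of hydrogen on a sulfur, the result is an at least 1.4-fold higher number from compound 1 to compound 3 (0.16 log units; that floor lies within the scatter), so a benzyl group on the sulfur does not by itself lower the number.

Compound 3 changes the substituent and its ring place together, and the compounds shown cannot separate the two. As far as these compounds go, how a plain phenyl ring, or an amine or a carboxylic acid on that ring, would read remains open.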